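Swapping one five-membered heteroaromatic ring for another

This account rests on a few compounds, and the source may have more. Where it says the series, first, only, none or still open, it means among the compounds named here.

Measured so far:
Compound 1 `COc1ccc(OCC(=O)N2CCC3(CC2)CN(Cc2ccc(OCC(C)C)cc2Cl)C3)cc1` — 20 nM
Compound 2 `COc1ccc(OCC(=O)N2CCC3(CC2)CN(Cc2ccc(-c4nnc(C)o4)cc2)C3)cc1` — 52 nM

Both compounds share the same core and were tested in an assay on HEK293 cells for antagonist activity at growth hormone secretagogue receptor type 1 (Homo sapiens); on this read-out lower numbers stand for stronger inhibition and higher numbers for weaker inhibition. Compound 1 gives 20 nM, and compound 2 gives 52 nM. Of the two numbers shown, compound 2 stands at the higher one, so its inhibition is the weaker of the pair.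

Compound 3 `COc1ccc(OCC(=O)N2CCC3(CC2)CN(Cc2ccc(-n4cccn4)cc2)C3)cc1` has not yet been measured. It differs from compound 2 in one place: 1H-pyrazol-1-yl in place of 5-methyl-1,3,4-oxadiazol-2-yl on an aromatic carbon. In words, 1H-pyrazol-1-yl takes the place of 5-methyl-1,3,4-oxadiazol-2-yl on an aromatic carbon, para to a large group. Nothing measured here shows how this kind of swap plays out, so no direction can be read from the data. The expected step of a 1.0-fold lower number from compound 2 to compound 3 (0.02 log units; within the scatter) in this assay is therefore small and uncertain, not clearly beyond the scatter either way. Compound 3 is estimated at 50 nM, with a likely range from 15 nM to 160 nM.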

Compound 3, inhibition constant: 152 nM
Compound 3: the middle estimate sits 3.0-fold (0.48 log units) below what was measured; measured number inside the range.
By their numbers in this assay, from the lowest: compound 1; then compound 2; then compound 3.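

At this position, on an aromatic carbon para to a large group, the identity of the five-membered ring matters. In this assay putting 1H-pyrazol-1-yl in place of 5-methyl-1,3,4-oxadiazol-2-yl gives a 2.9-fold higher number from compound 2 to compound 3 (0.47 log units; beyond the scatter) and so weaker inhibition, which makes the oxadiazole the better of these two rings here. Nothing available here accounts for the loss of inhibition.

The swap changes several things at once: the ring loses its oxygen, gains a different attachment through nitrogen and drops its methyl group, and this single step cannot separate those changes. On these data alone, how an unsubstituted 1,3,4-oxadiazol-2-yl ring or a 3-methyl-1H-pyrazol-1-yl group would behave at this position remains open, and either would help show whether the methyl group or the ring itself carries the difference.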